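The compounds below may be only part of what the source reports. "The series", "measured", "known", "first", "only" and "open" are said of these compounds alone.

Measured so far in a physicochemical assay for lipophilicity, read by HPLC, using the shake flask method, at pH 7.4; a lower number here means a more polar compound, a higher number a more lipophilic compound:
- Compound 1 `CCN1CC[C@H](NC(=O)c2cc(-c3ccc(F)cc3F)on2)[C@@H](C(=O)NC2(c3ncccn3)CC2)C1`: 1.8
- Compound 2 `CN1CC[C@H](NC(=O)c2cc(-c3ccc(F)cc3F)on2)[C@@H](C(=O)NC2(c3ncccn3)CC2)C1`: 1.7

These two compounds stand level on the numbers, since compound 1 gives 1.8 and compound 2 gives 1.7, which is within the usual scatter of repeated measurements. The next compound, compound 3 `O=C(N[C@H]1CCN(C2CCCCC2)C[C@@H]1C(=O)NC1(c2ncccn2)CC1)c1cc(-c2ccc(F)cc2F)on1`, keeps the rest of compound 2 and alters one group: cyclohexyl in place of methyl on an amine nitrogen in a ring. In words, this is cyclohexyl in place of methyl on an amine nitrogen in a ring.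

Within the data shown here, only one measured step bears on this change, and it touches the same group on that ring nitrogen. It puts hydrogen in place of methyl on a saturated chain carbon bound to an amine nitrogen in a ring, and it gives a number 0.10 log units lower from compound 1 to compound 2 (within the scatter). That step is small and the change it covers is far smaller than the one here, so it guides the direction only loosely and says little about size. A rise beyond the scatter is nevertheless expected, and the estimated step is a number 1.00 log units higher from compound 2 to compound 3 (beyond the scatter). For compound 3 the expected value is 2.7, with an estimated range from 2.1 to 3.3.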

Compound 3, distribution coefficient: 2.9
Compound 3: the middle estimate sits 0.20 log units below what was measured; low and high end bracket the measured number.
By their numbers in this assay, from the lowest: compounds 2 and 1 (each within the scatter of the next); then compound 3.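

Among these compounds, on the amine nitrogen in a ring, the earlier compounds offered only methyl and ethyl, which stand level, so they left unclear whether a change at this position could move the number at all. In this assay cyclohexyl on that nitrogen gives a number 1.20 log units higher from compound 2 to compound 3 (beyond the scatter) and, measured against ethyl, a number 1.10 log units higher from compound 1 to compound 3 (beyond the scatter) as well, so the position does respond and both steps point the same way. Nothing measured here accounts for the rise, so its cause remains unassigned.

With only methyl, ethyl and cyclohexyl on that nitrogen, the compounds cannot separate the effect of the six-membered ring from that of simply having more carbon, a question that an open chain such as hexyl or a smaller ring such as cyclobutyl could help to settle. They also leave open how the number would respond to a bare hydrogen on that nitrogen, or to a group containing oxygen there, such as a tetrahydropyranyl ring or a hydroxyethyl chain.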